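Uracil-linked phenoxyalkyl series: cytotoxicity working notes

The source may hold more compounds than are shown below. What is called first, only, known or untested is meant among the compounds shown, and "the series" means these compounds.

Measured so far:
compound 1 `O=c1ccn(CCCCCOc2ccc(-c3ccccc3)cc2)c(=O)[nH]1` — 100000 nM
compound 2 `O=c1ccn(CCCCCCCCOc2ccc(Br)cc2)c(=O)[nH]1` — >= 100000 nM

In an ADME assay on HEL cells (Homo sapiens) for cytotoxicity, read by microscopy (on this read-out lower numbers stand for higher toxicity in this test and higher numbers for lower toxicity in this test), compound 1 gives 100000 nM, the only number shown in this set. For compound 2 the result of >= 100000 nM is a limit of the assay, not a number, matching (the limit of >= 100000 nM in this assay, at which 1 of the 2 values shown sits). Compound 3 `Cc1ccc(OCCCCCn2ccc(=O)[nH]c2=O)cc1` differs from compound 1 by methyl in place of phenyl on an aromatic carbon. No step between measured compounds is shown, so the expected step of no change at the digits printed from compound 1 to compound 3 (within the scatter) is none beyond the scatter. Compound 3 is expected at 100000 nM, between 30000 nM and 200000 nM, likely reported only as a limit. This rests on compound 1 giving 100000 nM.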

Compound 3, minimum cytotoxic concentration: 100000 nM
The estimate for compound 3 equals the measured number at the digits printed, and the stated range covers the measured number.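

In this assay, methyl in place of phenyl on an aromatic carbon, para to a large group, gives no change at the digits printed from compound 1 to compound 3 (within the scatter). This position therefore carries either group, with one aromatic ring fewer in compound 3, without a shift in the read-out beyond the scatter. The flat step may say little about any underlying difference in toxicity, because the values lie at the edge of what this read-out reports: the limit of >= 100000 nM in this assay, at which 1 of the 3 values shown sits.

Open, going by these compounds, is whether an amine or a carboxylic acid at this position would move the read-out in this assay.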